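The compounds below may be only part of what the source reports. "The series", "measured", "known", "first", "only" and "open" are said of these compounds alone.

Measured compounds:
compound 1 `CC1=C(C(=O)OC(C)C)C(C2CCCC2)N/C(=N/C#N)N1` — in an assay on cells for displacement of a labelled ligand from adenosine receptor A1 (Homo sapiens), with a stated time of 60 min, tested at 1 uM (a lower number here means less inhibition, a higher number more inhibition at the concentration tested (going by the name of the read-out)), compound 1 gives 3%
compound 2 `CCOC(=O)C1=C(C)N/C(=N\C#N)NC1c1cccs1` — in this assay compound 2 gives 26%

Of the two numbers in hand, compound 1 stands lowest, and the nearest number, that of compound 2, lies above it by a margin beyond the usual scatter. Among the measured compounds shown here, compound 1 and compound 2 differ in more than one place, so their two values show only that compound 2 sits higher, nothing about which part of the difference carries it.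

The step under consideration leads from compound 1 to compound 3 `CC1=C(C(=O)OC(C)C)C(c2ccsc2)N/C(=N/C#N)N1`, in which the change is thiophen-3-yl in place of cyclopentyl on a saturated ring carbon. For the measured compounds named here, no single-change step between measured compounds is available to set a size for this move. In this assay a modest rise is expected, since compound 2, which also carries a thiophene ring on the shared core, gives 26%. The expected step is a number 12 percentage points higher from compound 1 to compound 3 (beyond the scatter). Compound 3 is accordingly estimated at 15%, within a range from 0% to 40%.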

Compound 3, a percentage reported as inhibition, at one concentration (the size of the read-out at that concentration, not a potency): 11%
Compound 3: middle estimate off by 4 percentage points, on the high side; low and high end bracket the measured number.
By their numbers in this assay, from the lowest: compounds 1 and 3 (each within the scatter of the next); then compound 2.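

In this assay, among the compounds shown here, placing thiophen-3-yl instead of cyclopentyl on the saturated ring carbon gives a number 8 percentage points higher from compound 1 to compound 3 (within the scatter) and so provides the first single-change reading at this position. With the isopropoxycarbonyl group and the rest of the shared core held constant, exchanging the non-aromatic carbon ring for the aromatic ring with a hetero atom leaves the read-out within the usual scatter at the tested concentration. No measured evidence is available to explain this result.

The compounds shown leave open how an aminomethyl group, a carboxylic acid or a longer alkyl chain on this ring carbon would read in this assay. They also leave open whether an ethoxycarbonyl group in place of the isopropoxycarbonyl group would shift the number on its own.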